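The source may hold more compounds than are shown below. What is called first, only, known or untested is meant among the compounds shown, and "the series" means these compounds.

Compound 2 `CCCCCCNc1cnc(C(=O)NCc2ccccc2)cn1` in an ADME assay on Vero cells (Chlorocebus sabaeus) for cytotoxicity, read by microscopy, with a stated time of 6 days (on this read-out higher numbers stand for lower toxicity in this test and lower numbers for higher toxicity in this test), gives >= 100000 nM, which is a limit of the assay rather than a measured value. Compound 1 `CCCCCCCNc1cnc(C(=O)NCc2ccccc2)cn1` in this assay gives >= 100000 nM, again a limit. Compound 3 `O=C(NCc1ccccc1)c1cncc(Cl)n1` in this assay gives "not determined" (no result reported), so it has no result there. Among the measured compounds shown here, the one step between measured compounds, a step that the two limits leave unreadable from compound 1 to compound 2, has limits at both ends, so its size is not readable. Compound 4 `CCCCCCCCNc1cnc(C(=O)NCc2ccccc2)cn1` differs from compound 2 by ethyl in place of hydrogen on a saturated chain carbon, six bonds along the chain from a nitrogen on an aromatic ring. For the measured compounds named here, the only guide is the limit of >= 100000 nM in this assay, at which 2 of the 3 values shown sit, and no readable step points in either direction, so no change beyond the scatter is expected in this assay. Compound 4 is therefore estimated at 100000 nM, between 50000 nM and 200000 nM. The expected step is a number no higher from compound 2 to compound 4 (the limit leaves the size open), most likely reported again only as a limit.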

Compound 4, minimum cytotoxic concentration: 20000 nM
For compound 4 the middle estimate is 5.0-fold (0.70 log units) above the measured one; the measured number lies below the stated range.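

In this assay, the chain position now gives a readable result: ethyl in place of hydrogen gives an at least 5.0-fold lower number from compound 2 to compound 4 (0.69 log units; beyond the scatter), and methyl in place of hydrogen gives an at least 5.0-fold lower number from compound 1 to compound 4 (0.69 log units; beyond the scatter). Among the compounds shown here, these are the first readable steps here, and both point towards higher toxicity in this test, whereas the step from the hexyl to the heptyl chain cannot be read. Both new steps start from a limit, so each could be larger: the limit of >= 100000 nM in this assay, at which 2 of the 4 values shown sit.

The compounds shown leave open whether a longer chain would lower the number further. They also leave open whether an amine or a carboxylic acid at the chain end would keep it near the value of compound 4.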